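Compound 3 to compound 4: methoxy gives way to nitro

The source may report more compounds than this note shows. Statements on the series, on what has been measured and on what is new or still open speak of the compounds shown alone.

Compound 1 `CCCCCC/C=C/C[C@H]1C[C@@H]([C@@H](O)c2ccccc2)CO[C@@H]1c1ccccc1`: 4990 nM
Compound 2 `Oc1ccc(/C=C/C[C@H]2C[C@@H]([C@@H](O)c3ccccc3)CO[C@@H]2c2ccccc2)cc1`: 7380 nM
Compound 3 `COc1ccc(/C=C/C[C@H]2C[C@@H]([C@@H](O)c3ccccc3)CO[C@@H]2c2ccccc2)cc1`: 9010 nM

In a functional assay on HL-60 cells (Homo sapiens) for cytotoxicity, read by WST assay, with a stated time of 48 h (a higher number here means a weaker inhibitor, a lower number a stronger inhibitor), compound 3 gives 9010 nM, which cannot be separated from the other two values: the measured 1.8-fold higher number from compound 1 to compound 3 (0.26 log units; within the scatter) and a 1.2-fold higher number from compound 2 to compound 3 (0.09 log units; within the scatter) both stay within the scatter. Compound 4 `O=[N+]([O-])c1ccc(/C=C/C[C@H]2C[C@@H]([C@@H](O)c3ccccc3)CO[C@@H]2c2ccccc2)cc1` carries nitro in place of methoxy on an aromatic carbon, para to a large group: nitro in place of methoxy on an aromatic carbon. Going by the values given here, no measured compound carries nitro, so no step measures this change directly. The nearest evidence is the same site, where methyl in place of hydrogen on the oxygen gave a 1.2-fold higher number from compound 2 to compound 3 (0.09 log units; within the scatter). Replacing hexyl with 4-hydroxyphenyl gave a 1.5-fold higher number from compound 1 to compound 2 (0.17 log units; within the scatter), also small. On these three compounds, no step beyond the scatter is expected in this assay, in either direction. The expected change is a 1.3-fold lower number from compound 3 to compound 4 (0.11 log units; within the scatter). For compound 4 the estimated value is 7000 nM, with an expected range from 3000 nM to 16000 nM.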

Compound 4, half-maximal inhibitory concentration: 4880 nM
Compound 4: middle estimate off by 1.4-fold (0.16 log units), on the high side, and the stated range covers the measured number.
By their numbers in this assay, from the lowest: compounds 4, 1, 2 and 3 (each within the scatter of the next).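

In this assay, all three new steps stay within the scatter: nitro in place of methoxy gives a 1.8-fold lower number from compound 3 to compound 4 (0.27 log units; within the scatter) on the aromatic carbon para to a large group, nitro in place of hydroxy gives a 1.5-fold lower number from compound 2 to compound 4 (0.18 log units; within the scatter) at the same place, and 4-nitrophenyl in place of hexyl gives a 1.0-fold lower number from compound 1 to compound 4 (0.01 log units; within the scatter) on the chain. Methoxy, hydroxy and nitro at this position therefore cannot be told apart in these cells, and the 4-nitrophenyl compound cannot be told apart from the hexyl compound. Nothing available explains why these changes leave the reading within the scatter.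

As far as these compounds go, whether an amine or a carboxylic acid on the same aromatic carbon, or a longer chain in place of hexyl, would also stay within the scatter remains open. So does whether any change elsewhere on the shared core would produce a step beyond it.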